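The source may hold more compounds than are shown below. What is called first, only, known or untested is meant among the compounds shown, and "the series" means these compounds.

Values in a functional assay on PC-3 cells (Homo sapiens) for inhibition, read by sulforhodamine B assay, with a stated time of 48 h, tested at 50 uM; a higher number here means more inhibition of growth at the concentration tested, a lower number less inhibition of growth:

- compound 1 `COc1cc2c(cc1CC=C(C)C)C(=O)C[C@@H](c1ccc(Oc3ccc(F)cc3)cc1)O2`: 19%
- compound 2 `COc1ccc([C@@H]2C/C(=N/OCc3cn(-c4ccc(Cl)cc4C)nn3)c3cc(CC=C(C)C)c(OC)cc3O2)cc1`: 49%
- compound 3 `COc1cc2c(cc1CC=C(C)C)/C(=N/NC(N)=O)C[C@@H](c1ccc(O)cc1)O2`: 67%

Compound 2 stands second of the three. Compound 3 at 67% lies higher and compound 1 at 19% lies lower, and both gaps from compound 2 are beyond the scatter.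

The next compound to be measured is compound 4 `COc1ccc([C@@H]2C/C(=N/OCc3cn(-c4ccc(NC(C)=O)cc4)nn3)c3cc(CC=C(C)C)c(OC)cc3O2)cc1`. It differs from compound 2 by 4-acetamidophenyl in place of 4-chloro-2-methylphenyl on an aromatic nitrogen of the five-membered aromatic ring with 3 nitrogen.

For the measured compounds named here, no two measured compounds differ in one place, so nothing shows directly how much this exchange matters in this assay. The expectation therefore stays close to compound 2 at 49%, with a slight downward lean that is judgement only and probably no change beyond the scatter. The expected step is a number 7 percentage points lower from compound 2 to compound 4 (within the scatter), an estimate with wide uncertainty. For compound 4 the estimated value is 42%, with an expected range from 22% to 62%.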

Compound 4, percent growth inhibition at one concentration: 2%
For compound 4 the middle estimate is 40 percentage points above the measured one, outside the stated range (below it).
By their numbers in this assay, from the lowest: compound 4; then compound 1; then compound 2; then compound 3.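

In this assay, the group on the aromatic nitrogen of the five-membered aromatic ring with 3 nitrogen clearly matters: 4-acetamidophenyl in place of 4-chloro-2-methylphenyl gives a number 47 percentage points lower from compound 2 to compound 4 (beyond the scatter). For the compounds shown here, this is the first single exchange that can be read, and it leaves compound 4 at 2%, so growth inhibition at the concentration tested is sensitive to this position. No measurement at hand bears on the reason for this step.

The exchange alters several features at once, and the drop cannot be assigned to the loss of the chlorine, the loss of the methyl or the arrival of the acetamide. Also open, as far as these compounds go, is how a phenyl carrying only a chlorine, or one carrying an amine, would read on this aromatic nitrogen.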